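This account rests on a few compounds, and the source may have more. Where it says the series, first, only, none or still open, it means among the compounds named here.

Measured so far in a functional assay (aorta) with Oryctolagus cuniculus as the target; on this read-out higher numbers stand for weaker inhibition and lower numbers for stronger inhibition:

- compound 1 `OCc1ccc(-c2nn(Cc3ccccc3F)c3ncccc23)o1` gives 1700 nM; 1700 nM (2 entries)
- compound 2 `Fc1ccccc1Cn1nc(-c2ccccn2)c2cccnc21` gives 4800 nM
- compound 3 `CC(C)c1cnc(-c2nn(Cc3ccccc3F)c3ncccc23)nc1N` gives 207000 nM

Among the two single numbers, compound 3 carries the highest one; the nearest entry is that of compound 2, and the gap between the two lies far beyond the usual scatter of repeated measurements. Compound 1 adds two entries that agree with each other and sit in the same region as compound 2, so compound 3 stands alone at the weak end of what has been measured in this assay.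

The next compound, compound 4 `NCc1cnc(-c2nn(Cc3ccccc3F)c3ncccc23)nc1N`, is compound 3 with one change: aminomethyl in place of isopropyl on an aromatic carbon. Among the measured compounds shown here, no pair of measured compounds shows this change, so there is no measured step to lean on; the three measured compounds differ from one another in other places and give no guide to what an aminomethyl in place of an isopropyl does here.

For the measured compounds named here, with no comparable step in hand, the expectation for compound 4 in this assay is a number close to that of compound 3, with the step of a 1.4-fold lower number from compound 3 to compound 4 (0.14 log units; within the scatter) expected to stay within or only just outside the scatter. The estimate for compound 4 is 150000 nM, expected to fall between 40000 nM and 500000 nM.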

Compound 4, half-maximal inhibitory concentration: 1400000 nM
For compound 4 the middle estimate is 9.3-fold (0.97 log units) below the measured one, and the stated range ends below it.
By their numbers in this assay, from the lowest: compound 2; then compound 3; then compound 4.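

In this assay, among the compounds shown here, replacing isopropyl with aminomethyl on the aromatic carbon ortho to the amino group gives a 6.8-fold higher number from compound 3 to compound 4 (0.83 log units; beyond the scatter), so this position is sensitive to the change, a point the earlier compounds could not address because no measured pair differed here. The step also extends the series further toward weaker inhibition, starting from a compound that already stood at the weak end of the measured set. The change removes 3 carbon and brings in 1 carbon and 1 nitrogen, adding 1 hydrogen-bond donor and 1 hydrogen-bond acceptor, but no measurement at hand bears on which of these differences accounts for the step.

A single step leaves open whether the nitrogen of aminomethyl or the loss of isopropyl matters more; hydroxymethyl, ethyl or dimethylaminomethyl on the same carbon would help separate the two. Also open, going by these compounds, is whether a carboxylic acid or a longer chain ending in an amine at this position would follow the same direction, and whether any group here can move the number toward stronger inhibition.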